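The compounds below may be only part of what the source reports. "The series", "measured", "known", "first", "only" and "open" are said of these compounds alone.

Of the compounds shown here, three that share one core have been measured in a functional assay on A-431 cells (Homo sapiens), tested at 0.1 uM; on this read-out lower numbers stand for less inhibition and higher numbers for more inhibition at the one concentration tested (going by the name of the read-out). Compound 1 `COc1cc(OC)cc(Oc2ncccc2-c2n[nH]c(Nc3cccc(O)c3)n2)c1` gives 86% in this assay, and compound 2 `COc1cc(OC)cc(Oc2ncccc2-c2n[nH]c(Nc3ccc(N(C)C)cc3)n2)c1` gives 86%. Compound 3 `COc1cc(OC)cc(Oc2ncccc2-c2n[nH]c(Nc3ccc(C#N)cc3)n2)c1` gives 27%, the lowest of the three numbers. The step of no change at the digits printed from compound 1 to compound 2 (within the scatter) shows that exchanging one aryl group for another can leave the read-out untouched, whereas a number 59 percentage points lower from compound 1 to compound 3 (beyond the scatter) and a number 59 percentage points lower from compound 2 to compound 3 (beyond the scatter) are both large drops, so the 4-cyanophenyl group of compound 3 goes with far weaker inhibition than either of the other two aryl groups on a nitrogen on an aromatic ring.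

Compound 4 `COc1cc(OC)cc(Oc2ncccc2-c2n[nH]c(Nc3cc(F)cc(F)c3)n2)c1` has not yet been measured. Its difference from compound 3 is 3,5-difluorophenyl in place of 4-cyanophenyl on a nitrogen on an aromatic ring. Going by the values given here, the steps that bear on this change are the two that lead into compound 3, a number 59 percentage points lower from compound 1 to compound 3 (beyond the scatter) and a number 59 percentage points lower from compound 2 to compound 3 (beyond the scatter); both show that the 4-cyanophenyl group sits well below the alternatives tried, and compound 4 removes that group. Among the compounds with values here, no measured compound carries a 3,5-difluorophenyl group, so how far the number climbs back is uncertain. The expected step of a number 33 percentage points higher from compound 3 to compound 4 (beyond the scatter) is therefore upward and sizeable, though with a wide margin. Compound 4 is estimated at 60%, within 25% to 88%.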

Compound 4, a percentage reported as inhibition, at one concentration (the size of the read-out at that concentration, not a potency): 27%
The estimate for compound 4 lay 33 percentage points above the measured number; the measured number falls inside the stated range.
By their numbers in this assay, from the lowest: compounds 3 and 4 (each within the scatter of the next); then compounds 1 and 2 (each within the scatter of the next).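

In this assay, the result is no change at the digits printed from compound 3 to compound 4 (within the scatter), so replacing the 4-cyanophenyl group does not by itself lift the read-out, and the low number of compound 3 cannot be tied to the nitrile alone. The steps of a number 59 percentage points lower from compound 1 to compound 4 (beyond the scatter) and a number 59 percentage points lower from compound 2 to compound 4 (beyond the scatter) show that the 3,5-difluorophenyl group also falls far short of the 3-hydroxyphenyl and 4-(dimethylamino)phenyl groups on this nitrogen. Among these four compounds, the aryl groups therefore form two clear pairs, with the hydroxy and dimethylamino groups on the high side and the cyano and fluoro groups on the low side, but nothing measured here explains that division.

The aryl groups differ both in their substituents and in where those substituents sit, so the compounds shown cannot separate these two changes. As far as these compounds go, it remains open whether a 4-hydroxyphenyl, 3-(dimethylamino)phenyl or 3-aminophenyl group would join the high pair, which would show whether the substituent itself or its place on the ring matters more.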